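Notes on a trifluoromethyl-for-methyl step across two cores

The compounds below may be only part of what the source reports. "The series", "measured", "known", "first", "only" and "open" are said of these compounds alone.

Of the compounds shown here, three have been measured in a functional assay on HepG2 cells (Homo sapiens) for cytotoxicity, read by MTT assay, with a stated time of 72 h; on this read-out lower numbers stand for stronger inhibition and higher numbers for weaker inhibition. Compound 1 `COc1ccc2ccc(=O)oc2c1C(/C=C/c1ccc(C(F)(F)F)cc1)=N/NC(N)=O` gives 96 nM. Its counterpart, compound 2 `COc1ccc2ccc(=O)oc2c1C(/C=C/c1ccc(C)cc1)=N/NC(N)=O`, gives 93 nM in this assay. Compound 3 `COc1ccc2ccc(=O)oc2c1C1=NN(C(C)=O)C(c2ccc(C)cc2)C1`, built on a different core, gives 50 nM in this assay; its gaps to compound 1 and to compound 2 both lie within the scatter, so the three values cannot be separated from one another.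

Compound 2 and compound 1 differ in one place only, (trifluoromethyl in place of methyl on an aromatic carbon). In this assay this gave a 1.0-fold higher number from compound 2 to compound 1 (0.01 log units; within the scatter), a step within the scatter. The difference between the core of compound 2 and the core of compound 3 is not broken down here.

Compound 4 `COc1ccc2ccc(=O)oc2c1C1=NN(C(C)=O)C(c2ccc(C(F)(F)F)cc2)C1` is not yet measured. It stands to compound 3 as compound 1 stands to compound 2: the change is trifluoromethyl in place of methyl on an aromatic carbon, at the same place as before, so it is the same change made on the other core. On that basis the expected step is no change at the digits printed from compound 3 to compound 4 (within the scatter), because a 1.0-fold higher number from compound 2 to compound 1 (0.01 log units; within the scatter) showed no movement on the first core. The estimate for compound 4 in this assay is 50 nM, with a range from 25 nM to 100 nM. Whether the second core answers the change in the same way rests on that single precedent.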

Compound 4, half-maximal inhibitory concentration: 80 nM
Compound 4: middle estimate off by 1.6-fold (0.20 log units), on the low side; the range from low to high includes it.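

In this assay, trifluoromethyl in place of methyl on the second core gives a 1.6-fold higher number from compound 3 to compound 4 (0.20 log units; within the scatter), so on this core too the step does not rise above the usual scatter of repeated measurements. Set beside the earlier step, the change reads alike on both cores: the same change on two cores in this assay, a 1.0-fold higher number (0.01 log units; within the scatter) from compound 2 to compound 1 and a 1.6-fold higher number (0.20 log units; within the scatter) from compound 3 to compound 4, 1.6-fold (0.19 log units) apart, within the scatter of two such steps. This shows that nothing measured here separates the two cores in their answer to this one change, but it does not show that they answer identically, as two steps within the scatter can neither confirm nor exclude a small real difference, and it says nothing about carrying the change to any further core or about any other pair of groups.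

The compounds shown leave open how either core answers a group other than methyl or trifluoromethyl at this place on the six-membered aromatic ring, such as an amine, a carboxylic acid or a chlorine atom. From the compounds shown here alone, with four compounds on a single cell line, it also stays open whether the same flat reading would hold on other cells.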